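From pyridin-2-yl to quinolin-5-yl on the shared core

This account rests on a few compounds, and the source may have more. Where it says the series, first, only, none or still open, it means among the compounds named here.

In a physicochemical assay for solubility, in phosphate buffer, at pH 7.4 (a higher number here means a more soluble compound, a lower number a less soluble compound), compound 3 `c1ccc(-c2nccnc2OC2CN(c3ccc4ccccc4n3)C2)nc1` gives 349000 nM, the highest measured number here. Compound 1 `OCC1CCN(c2nccnc2OC2CN(c3ccc4ccccc4n3)C2)C1` gives 167000 nM, and a 2.1-fold higher number from compound 1 to compound 3 (0.32 log units; beyond the scatter) is a modest step. Compound 2 `c1ccc2nc(N3CC(Oc4nccnc4N4CCCCC4)C3)ccc2c1` is reported only as a limit, < 1000 nM.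

Compound 4 `c1ccc2nc(N3CC(Oc4nccnc4-c4cccc5ncccc45)C3)ccc2c1` carries quinolin-5-yl in place of pyridin-2-yl on an aromatic carbon, (quinolin-5-yl in place of pyridin-2-yl on an aromatic carbon). All three measured steps are changes at this same place, and two are large: an at least 160-fold lower number from compound 1 to compound 2 (2.22 log units; beyond the scatter) and an at least 340-fold higher number from compound 2 to compound 3 (2.54 log units; beyond the scatter). None involves quinolin-5-yl, so they show only how far this place can move the number. With compound 3 at 349000 nM, a large fall in this assay is expected, the estimated step being a 12-fold lower number from compound 3 to compound 4 (1.07 log units; beyond the scatter). For compound 4 the estimate is 30000 nM, within an expected range of 2000 nM to 250000 nM.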

Compound 4, solubility: 47000 nM
The estimate for compound 4 lay 1.6-fold (0.19 log units) below the measured number, within the range that was stated.
By their numbers in this assay, from the lowest: compound 4; then compound 1; then compound 3. At a limit, below all of these: compound 2.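

At this place, quinolin-5-yl, which adds a six-membered aromatic ring of carbon only to what pyridin-2-yl carries, stands under both other measured groups in this assay: a 7.4-fold lower number from compound 3 to compound 4 (0.87 log units; beyond the scatter) and a 3.6-fold lower number from compound 1 to compound 4 (0.55 log units; beyond the scatter). Its gain over piperidin-1-yl, an at least 47-fold higher number from compound 2 to compound 4 (1.67 log units; beyond the scatter), rests on a value for compound 2 that is only a limit: the limit of < 1000 nM in this assay, at which 1 of the 4 values shown sits. Both aromatic groups therefore sit well clear of that limit, and piperidin-1-yl alone reaches it. From the compounds shown here alone, whether phenyl would fall nearer compound 3 or compound 4 remains open, as does the effect of an amine on quinolin-5-yl.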